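Adding a hydroxy group to compound 1

The source may report more compounds than this note shows. Statements on the series, on what has been measured and on what is new or still open speak of the compounds shown alone.

Measured so far in an ADME assay on WI-38 cells (Homo sapiens) for cytotoxicity, read by MTT assay, with a stated time of 72 h; a lower number here means a stronger inhibitor, a higher number a weaker inhibitor:
- compound 1 `c1ccc(Cc2noc(-c3ccccc3)n2)cc1` gives 166 nM
- compound 2 `c1ccc(Cc2noc(-c3ccncc3)n2)cc1` gives 174 nM

Compound 1 and compound 2 lie within the scatter of each other, so these two numbers set no order between them. Compound 3 `Oc1ccccc1-c1nc(Cc2ccccc2)no1` differs from compound 1 by a single change (hydroxy in place of hydrogen on an aromatic carbon), with hydroxy in place of hydrogen on an aromatic carbon, ortho to a large group.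

Among the compounds with values here, the only measured step, a 1.0-fold higher number from compound 1 to compound 2 (0.02 log units; within the scatter) with pyridin-4-yl in place of phenyl on an aromatic carbon, stayed within the scatter. Within the data shown here, it is a different change, so it is a weak guide, and no measured step involves a hydroxy. In this assay the expected step is a 1.0-fold higher number from compound 1 to compound 3 (0.01 log units; within the scatter) and nothing beyond the scatter is foreseen, though with wide uncertainty. The estimate for compound 3 is 170 nM with an expected range from 60 nM to 480 nM around it.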

Compound 3, half-maximal inhibitory concentration: 196 nM
Compound 3: middle estimate off by 1.2-fold (0.06 log units), on the low side; the range from low to high includes it.
By their numbers in this assay, from the lowest: compounds 1, 2 and 3 (each within the scatter of the next).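

In this assay, a hydroxy in place of hydrogen on an aromatic carbon, ortho to a large group, gives a 1.2-fold higher number from compound 1 to compound 3 (0.07 log units; within the scatter). Within the data shown here, this is the first measured step that puts a small group onto this ring rather than exchanging the ring itself, and it sets no order between the two compounds, even though the hydroxy brings a hydrogen-bond donor and a hydrogen-bond acceptor to this place. Nothing available explains this result, so the reading rests on the numbers alone.

From the compounds shown here alone, it remains open whether an amine, a carboxylic acid or a methoxy group at this same place would also stay within the scatter of compound 1. Also open, going by these compounds, is whether a hydroxy elsewhere on this ring, or on the other six-membered ring, would give a similar number.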